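A few compounds are considered here, and "the series" means these few. Any claim that something is new, unique, unknown or untested is made for them only; others in the source may bear on it.

Compound 1 `CC(=O)O[C@@H]1OC(=O)[C@](C)(C(C)=O)[C@@H]1C` is the shared core of this small set, a five-membered lactone carrying an acetoxy group, an acetyl group and two methyl groups. Going by the values given here, in a functional assay on HT-29 cells (Homo sapiens) for cytotoxicity, read by MTT assay (a higher number here means a weaker inhibitor, a lower number a stronger inhibitor), compound 1 gives 5000 nM, and it is the only compound of the three measured that returns a number rather than a limit. Compound 2 `CC(=O)O[C@@H]1OC(=O)[C@@](C(C)=O)(C2SCCCS2)[C@@H]1C` reaches only the limit of the assay, > 50000 nM. Compound 3 `CC(=O)O[C@@H]1OC(=O)[C@](OC(C)=O)(C(C)=O)[C@@H]1C` likewise sits at the limit, > 50000 nM. Both changes, a dithiane ring in place of methyl and acetoxy in place of methyl, cost potency: an at least 10-fold higher number from compound 1 to compound 2 (1.00 log units; beyond the scatter) and an at least 10-fold higher number from compound 1 to compound 3 (1.00 log units; beyond the scatter). The step between compound 2 and compound 3 cannot be read, since both sit at the limit of > 50000 nM in this assay, at which 2 of the 3 values shown sit.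

Compound 4 `CC(=O)O[C@@H]1OC(=O)[C@](C)(C(C)=O)[C@@H]1C(C)C` changes compound 1 at a different ring carbon: isopropyl in place of methyl on a saturated ring carbon. Among the compounds with values here, no measured step touches this position, so the two measured steps bear on it only indirectly, as a sign that enlarging a substituent on the core of compound 1 has so far weakened it. Compound 4 is therefore expected to show a modest weakening, a 2.4-fold higher number from compound 1 to compound 4 (0.38 log units; beyond the scatter), smaller than the steps to compound 2 and compound 3. The estimate for compound 4 in this assay is 12000 nM, within a range from 3000 nM to 45000 nM.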

Compound 4, half-maximal inhibitory concentration: > 50000 nM
Compound 4 gave a limit, no number; the forecaster's own chance of this, stated with the estimate: 25%; middle value at least 4.1-fold (0.61 log units) away from the limit.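

Among the compounds shown, only compound 4 carries a change at the saturated ring carbon two ring bonds from the ring oxygen, and the swap of methyl for isopropyl there gives an at least 10-fold higher number from compound 1 to compound 4 (1.00 log units; beyond the scatter). The loss seen in this assay is therefore not confined to the ring carbon changed in compound 2 and compound 3, and at this second position a group with no ring and no hydrogen-bond donors or acceptors is enough to bring it about. The step gives only a lower bound on the size of the loss, because compound 4 ends at the same limit of the assay as compound 2 and compound 3: the limit of > 50000 nM in this assay, at which 3 of the 4 values shown sit.

Going by these compounds, what stays open is how the response runs between methyl and isopropyl at this position, and whether an ethyl group there would keep a measurable value in this assay. Also open, on these data alone, is whether a group of another kind on this ring carbon, such as an amine or a hydroxymethyl group, would fare any differently from isopropyl on the core of compound 1.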